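A few compounds are considered here, and "the series" means these few. Any claim that something is new, unique, unknown or untested is made for them only; others in the source may bear on it.

The study sets compound 3 `CC(=O)Nc1ccc(-c2nc3ccccc3[nH]2)cc1`, compound 1 `CC(=O)Nc1ccc(-c2nc3cc([N+](=O)[O-])ccc3[nH]2)cc1` and compound 2 `COc1ccc(-c2nc3cc(C(F)(F)F)ccc3[nH]2)cc1` beside the as yet unmeasured compound 4 `COc1ccc(-c2nc3cc(C(F)(F)F)ccc3[nH]2)c([N+](=O)[O-])c1` in an ADME assay on BHK cells (Mesocricetus auratus) for cytotoxicity, read by MTT assay, with a stated time of 96 h; a higher number here means that more compound is tolerated, a lower number that less compound is tolerated. In this assay compound 3 gives > 100000 nM, which is a limit of the assay and not a number. In this assay compound 1 gives > 100000 nM, again a limit. In this assay compound 2 gives > 100000 nM, also a limit. The change from compound 3 to compound 1 is nitro in place of hydrogen on an aromatic carbon, and the step it made, a step that the two limits leave unreadable from compound 3 to compound 1, stays unreadable because of the limit of > 100000 nM in this assay, at which 3 of the 3 values shown sit. The difference between the cores of compound 2 and compound 3 is not broken down here. Compound 4 arises from compound 2 by nitro in place of hydrogen on an aromatic carbon. Within the data shown here, this is the same kind of change as the one from compound 3 to compound 1, though the surroundings differ: in compound 1 the nitro sits on a ring that is part of a fused or bridged system of two rings, meta to a fused ring and para to a fused ring, whereas in compound 4 it sits ortho to a large group and meta to a methoxy group. Because all three measured values sit at the limit of > 100000 nM in this assay, at which 3 of the 3 values shown sit, compound 4 is expected to remain at the limit as well, which would be a step that the limit leaves unreadable from compound 2 to compound 4. Compound 4 is accordingly estimated at 150000 nM, within a range from 60000 nM to 400000 nM, an expectation resting on the limits alone and on no readable step.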

Compound 4, half-maximal cytotoxic concentration: 100000 nM
Compound 4: middle estimate off by 1.5-fold (0.18 log units), on the high side; measured number inside the range.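

In this assay, nitro in place of hydrogen on an aromatic carbon, carried onto the core of compound 2, gives a number no higher from compound 2 to compound 4 (the limit leaves the size open). Among these compounds, this shows that on this core the change leaves the number level with the limit or under it, and compound 4 is the one compound of the four with a number rather than a limit. It does not show whether the number moved at all, and neither this step nor the same change on the core of compound 3 has a readable size, so the two steps cannot be set against each other and nothing shows that the change carries over from one core to the other with the same result: the limit of > 100000 nM in this assay, at which 3 of the 4 values shown sit.

The compounds shown leave open what nitro does on this ring at any place other than the one in compound 4, ortho to a large group and meta to a methoxy group. They also leave open whether an amine or a carboxylic acid in that same place would give a number clear of the limit in this assay, which is what a readable step on this core would need.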